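The compounds below may be only part of what the source reports. "The series", "measured", "known", "first", "only" and "open" are said of these compounds alone.

Of the compounds shown here, three have been measured in a physicochemical assay for solubility, at pH 7.4; on this read-out lower numbers stand for lower solubility and higher numbers for higher solubility. Compound 1 (`NS(=O)(=O)c1ccc(S(=O)(=O)CCCO)c(F)c1`) gives 6600 ug/mL, the second highest of the three numbers. The highest number comes from compound 3 (`COC(=O)c1cc(S(N)(=O)=O)ccc1S(=O)(=O)CCO`), which gives 33400 ug/mL. The lowest number comes from compound 2 (`NS(=O)(=O)c1ccc(SCCCCO)c(F)c1`), which gives 1000 ug/mL. Within the data shown here, both gaps from compound 1 lie beyond the usual scatter, but these compounds differ from one another in more than one place, so no measured step isolates a single change.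

Compound 4 (`Nc1cc(S(N)(=O)=O)ccc1S(=O)(=O)CCCO`) departs from compound 1 in one place: amino in place of fluoro on an aromatic carbon. In words, it carries amino in place of fluoro on an aromatic carbon. Among the measured compounds shown here, no measured pair shows this swap in this assay, so the expectation stays anchored on compound 1 at 6600 ug/mL. A small downward step is expected, possibly none beyond the scatter. The estimated step is a 1.7-fold lower number from compound 1 to compound 4 (0.22 log units; within the scatter). Compound 4 is estimated at 4000 ug/mL, with an expected range of 1500 ug/mL to 11000 ug/mL.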

Compound 4, solubility: 8400 ug/mL
Compound 4: the middle estimate sits 2.1-fold (0.32 log units) below what was measured; low and high end bracket the measured number.
By their numbers in this assay, from the lowest: compound 2; then compounds 1 and 4 (each within the scatter of the next); then compound 3.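

In this assay, the step of a 1.3-fold higher number from compound 1 to compound 4 (0.10 log units; within the scatter) comes with amino in place of fluoro on an aromatic carbon, ortho to a group of 7 heavy atoms and meta to a sulfamoyl group (4 heavy atoms). It is the first measured step among these compounds that isolates a single change, and it shows that this read-out does not separate the two groups at this position, even though amino adds 1 hydrogen-bond donor and 1 hydrogen-bond acceptor to the count. Nothing at hand accounts for this outcome.

The compounds shown leave open whether other groups at this position, such as a methoxy group or a carboxylic acid, would also stay within the scatter of compound 1. They also leave open whether the same swap would read alike with a longer chain on the sulfonyl group.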